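The source may hold more compounds than are shown below. What is called first, only, known or untested is meant among the compounds shown, and "the series" means these compounds.

Of the compounds shown here, three sharing one core have been tested in a functional assay on HCT-116 cells (Homo sapiens) for inhibition, read by MTT assay, with a stated time of 48 h; on this read-out lower numbers stand for stronger inhibition and higher numbers for weaker inhibition. Compound 1 `COc1ccc(N(C)c2nc(C)nc3ccccc23)cc1OCCN` gives 198 nM. Compound 2 `COc1ccc(N(C)c2nc(C)nc3ccccc23)cc1C(=O)NCC[Se]C#N` gives 313 nM, and compound 3 `COc1ccc(N(C)c2nc(C)nc3ccccc23)cc1C(=O)OCCC[Se]C#N` gives 720 nM. Compound 3 thus shows the highest number of the three, standing closest to compound 2 and farthest from compound 1. Compound 4 `COc1ccc(N(C)c2nc(C)nc3ccccc23)cc1C(=O)OCCCCC[Se]C#N` differs from compound 3 in a single place: a group of 5 heavy atoms (3 carbon, 1 nitrogen, 1 selenium; no ring) in place of a group of 3 heavy atoms (1 carbon, 1 nitrogen, 1 selenium; no ring), on a saturated chain carbon, three bonds along the chain from an oxygen next to a carbonyl group. Among the measured compounds shown here, no measured step changes exactly this part of the molecule, but two steps alter the same side chain. The step of a 2.3-fold higher number from compound 2 to compound 3 (0.36 log units; beyond the scatter) exchanged an amide-linked chain for an ester-linked one, and a 3.6-fold higher number from compound 1 to compound 3 (0.56 log units; beyond the scatter) replaced a short amine-bearing chain with the whole ester chain. Both moved the number upward by a modest amount. Extending the chain still further is therefore expected to raise the number only modestly, if at all: a 1.4-fold higher number from compound 3 to compound 4 (0.14 log units; within the scatter). Compound 4 is accordingly estimated at 1000 nM, within a range from 400 nM to 2500 nM.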

Compound 4, half-maximal inhibitory concentration: 551 nM
Compound 4: middle estimate off by 1.8-fold (0.26 log units), on the high side; measured number inside the range.
By their numbers in this assay, from the lowest: compounds 1, 2, 4 and 3 (each within the scatter of the next, the first and the last beyond it).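

In this assay, putting the group of 5 heavy atoms in place of the group of 3 heavy atoms, on a saturated chain carbon, three bonds along the chain from an oxygen next to a carbonyl group, gives a 1.3-fold lower number from compound 3 to compound 4 (0.12 log units; within the scatter) and so leaves the two compounds indistinguishable: across this change in chain length, the assay resolves no difference. The amide-linked compound 2 and the longer ester are also indistinguishable, with a 1.8-fold higher number from compound 2 to compound 4 (0.25 log units; within the scatter). The gap between compound 2 and compound 3, by contrast, lies beyond the scatter. No supporting measurement is available to explain these results.

On these data alone, whether a still longer chain would give a number beyond the scatter remains open. So does the effect of a sulfur atom in place of the selenium on this chain.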